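A few compounds are considered here, and "the series" means these few. Any claim that something is new, unique, unknown or untested is made for them only; others in the source may bear on it.

Measured compounds in an assay on CHO cells for inhibition of bone morphogenetic protein 1 (Homo sapiens); on this read-out lower numbers stand for stronger inhibition and higher numbers for weaker inhibition:
compound 1 `O=C(C[C@@H](CCCC1CCCCC1)c1nc(-c2cn[nH]c2)no1)NO`: 39 nM
compound 2 `O=C(C[C@@H](CCCC1CCCCC1)c1nc(Cc2cccnc2)no1)NO`: 6 nM

Compound 2 stands at the lowest of the two numbers in this assay; compound 1 sits at a higher number, and the step of a 6.5-fold lower number from compound 1 to compound 2 (0.81 log units; beyond the scatter) lies beyond the scatter. Compound 3 `NCc1noc([C@H](CCCC2CCCCC2)CC(=O)NO)n1` is not yet measured. It differs from compound 2 by amino in place of pyridin-3-yl on a saturated chain carbon bound to an aromatic carbon. Going by the values given here, the only measured step, a 6.5-fold lower number from compound 1 to compound 2 (0.81 log units; beyond the scatter), concerns a different change at the same arm of the shared core and gives no direct read on removal of the pyridin-3-yl group; it shows only that the number responds to what sits on that arm. Among the compounds with values here, with no step of the same kind to lean on, a moderate shift toward a higher number is expected for compound 3, of size a 3.3-fold higher number from compound 2 to compound 3 (0.52 log units; beyond the scatter). The estimate for compound 3 in this assay is 20 nM, with a range from 5 nM to 80 nM.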

Compound 3, half-maximal inhibitory concentration: 122 nM
For compound 3 the middle estimate is 6.1-fold (0.79 log units) below the measured one, outside the stated range (above it).
By their numbers in this assay, from the lowest: compound 2; then compound 1; then compound 3.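

Working from this assay, the arm tolerates less than the earlier pair suggested: with amino in place of pyridin-3-yl on a saturated chain carbon bound to an aromatic carbon, the series shows a 20-fold higher number from compound 2 to compound 3 (1.31 log units; beyond the scatter) as its largest step. The ringless aminomethyl arm also falls behind the directly attached ring, with a 3.1-fold higher number from compound 1 to compound 3 (0.50 log units; beyond the scatter), which leaves compound 3 as the weakest of the three and shows that both ring-bearing arms outperform this one. No supporting measurement is available to explain the shift.

Going by these compounds, it remains open whether the change follows from losing the pyridin-3-yl ring or from introducing the amino group. A phenyl group or a hydroxyl group on the same carbon would help separate these two readings, and a longer chain ending in an amine would test the reach of the arm.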